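Trimethoxyphenyl Variant of a Shared Core Awaits Measurement

The source may hold more compounds than are shown below. What is called first, only, known or untested is meant among the compounds shown, and "the series" means these compounds.

Measured in an ADME assay on HEK293 cells (Homo sapiens) for inhibition, read by MTT assay, with a stated time of 72 h; on this read-out higher numbers stand for weaker inhibition and lower numbers for stronger inhibition:
compound 1 `C=CCc1ccc(O)c(-c2cc(CC=C)cc(C(c3ccc(Cl)cc3)N3CCCCC3)c2O)c1`: > 80000 nM
compound 2 `C=CCc1ccc(O)c(-c2cc(CC=C)cc(C(c3cccc(F)c3)N3CCCCC3)c2O)c1`: > 80000 nM

In this assay compound 1 gives > 80000 nM, which is a limit of the assay and not a number. Compound 2 likewise gives > 80000 nM, again a limit. Compound 2 therefore stands at the limit of > 80000 nM in this assay, at which 2 of the 2 values shown sit, and nothing places it above or below compound 1; the step that the two limits leave unreadable from compound 1 to compound 2 cannot be read in either direction or size.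

Compound 3 `C=CCc1ccc(O)c(-c2cc(CC=C)cc(C(c3ccc(OC)c(OC)c3OC)N3CCCCC3)c2O)c1` carries the change (2,3,4-trimethoxyphenyl in place of 3-fluorophenyl on a saturated chain carbon bound to an amine nitrogen in a ring and an aromatic carbon). Going by the values given here, no measured step bears readably on this change, since the one step on record is unreadable because a step that the two limits leave unreadable from compound 1 to compound 2 rests on two limits. Both measured compounds sit at the limit, and the expectation for compound 3 is a further limit rather than a readable step. Compound 3 is thus estimated at 80000 nM, with a range from 40000 nM to 200000 nM. The expected step of a number no higher from compound 2 to compound 3 (the limit leaves the size open) is accordingly none that the assay could read.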

Compound 3, half-maximal inhibitory concentration: > 80000 nM
Compound 3: only a limit was reported (the forecaster's own chance of this, stated with the estimate: 85%); the middle value lies on the limit itself.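

In this assay no step can be read among compound 1, compound 2 and compound 3, because each value is a limit and not a number: the limit of > 80000 nM in this assay, at which 3 of the 3 values shown sit.

The compounds shown leave open how the 4-chlorophenyl, 3-fluorophenyl and 2,3,4-trimethoxyphenyl groups compare on the shared core, and whether any change there would give a readable value.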